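From 2-Bromobenzyl to 4-(Trifluoromethyl)benzyl at the Assay Limit

The compounds below may be only part of what the source reports. "The series", "measured", "known", "first", "only" and "open" are said of these compounds alone.

Compound 1 `COc1cc(OC)c(-c2coc3cc(OCc4cccc(Cl)c4)ccc3c2=O)cc1OC` and compound 2 `COc1cc(OC)c(-c2coc3cc(OCc4ccccc4Br)ccc3c2=O)cc1OC` share one core and were both tested in a functional assay on HUVEC cells (Homo sapiens) for antiproliferative activity, read by MTT assay, with a stated time of 24 h; on this read-out lower numbers stand for stronger inhibition and higher numbers for weaker inhibition. Compound 1 gives > 10000 nM, which is a limit and not a number. Compound 2 gives > 10000 nM, again only a limit. Both sit at the limit of > 10000 nM in this assay, at which 2 of the 2 values shown sit, so compound 2 offers no exact value to start from. Among the compounds with values here, the only measured step is a step that the two limits leave unreadable from compound 1 to compound 2, and it provides no size to carry forward. Compound 3 `COc1cc(OC)c(-c2coc3cc(OCc4ccc(C(F)(F)F)cc4)ccc3c2=O)cc1OC` keeps the core and changes one group: 4-(trifluoromethyl)phenyl in place of 2-bromophenyl on a saturated chain carbon bound to an oxygen on an aromatic ring. With compound 2 at > 10000 nM, no clear gain in this assay is expected, and another limit is the likeliest result. The expected step is a step that the limit leaves unreadable from compound 2 to compound 3, an estimate with no measured size behind it. Compound 3 is estimated at 15000 nM, with an expected range of 5000 nM to 40000 nM.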

Compound 3, half-maximal inhibitory concentration: > 10000 nM
Compound 3 gave a limit, no number; the forecaster's own chance of this, stated with the estimate: 85%; the middle value lies beyond the limit too.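

No size can be read for any step among compound 1, compound 2 and compound 3 in this assay, because each result is a limit and not a number: the limit of > 10000 nM in this assay, at which 3 of the 3 values shown sit.

The compounds shown leave open whether any other group in this place on the shared core would give an actual number.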